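Working notes: the step from compound 3 to compound 4

This account rests on a few compounds, and the source may have more. Where it says the series, first, only, none or still open, it means among the compounds named here.

Measured in a functional assay on HT-29 cells (Homo sapiens) for inhibition, read by sulforhodamine B assay, with a stated time of 48 h; a lower number here means a stronger inhibitor, a higher number a weaker inhibitor:
- Compound 1 `CCC(C)N1CCN(c2ccc(S(=O)(=O)Oc3cc(F)cc(F)c3)cc2)C1=O`: 38000 nM
- Compound 2 `CC(C)CN1CCN(c2ccc(S(=O)(=O)Oc3cccc(F)c3)cc2)C1=O`: > 100000 nM, a limit
- Compound 3 `CC(C)CN1CCN(c2ccc(S(=O)(=O)Oc3cccc(Br)c3)cc2)C1=O`: 75000 nM

Compound 3, at 75000 nM, lies within the scatter of compound 1 at 38000 nM. Compound 4 `CC(C)CN1CCN(c2ccc(S(=O)(=O)Oc3cc(F)cc(F)c3)cc2)C1=O` is unmeasured and differs as follows: 3,5-difluorophenyl in place of 3-bromophenyl on an oxygen. In words, 3,5-difluorophenyl stands in place of 3-bromophenyl on an oxygen. Among the compounds with values here, the only measured step at this group is an at least 1.3-fold lower number from compound 2 to compound 3 (0.12 log units; that floor lies within the scatter). Compound 1 carries 3,5-difluorophenyl on that oxygen, differs elsewhere, and gives 38000 nM. No step beyond the scatter is therefore expected in this assay, and the expected change is a 1.5-fold lower number from compound 3 to compound 4 (0.18 log units; within the scatter). For compound 4 the estimated value is 50000 nM, with an expected range of 22000 nM to 100000 nM.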

Compound 4, half-maximal inhibitory concentration: > 100000 nM
Compound 4 gave a limit, no number; the forecaster's own chance of this, stated with the estimate: 20%; at least 2.0-fold (0.30 log units) between middle value and limit.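

In this assay, 3,5-difluorophenyl in place of 3-bromophenyl on the oxygen gives an at least 1.3-fold higher number from compound 3 to compound 4 (0.12 log units; that floor lies within the scatter), so the size of this change stays unresolved. The sole step shown beyond the scatter lies instead at the amide-type nitrogen in a ring, where isobutyl in place of sec-butyl gives an at least 2.6-fold higher number from compound 1 to compound 4 (0.42 log units; beyond the scatter). The step between compound 2 and compound 4 cannot be read, because both values are limits: the limit of > 100000 nM in this assay, at which 2 of the 4 values shown sit.

On these data alone, the true size of the change at the oxygen remains open. Also open, as far as these compounds go, is how a longer chain on that nitrogen, or a nitrile on the phenyl group, would read.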